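This account rests on a few compounds, and the source may have more. Where it says the series, first, only, none or still open, it means among the compounds named here.

Measured compounds:
- compound 1 `CC(C)[C@H](NC(=O)c1ccc(Br)cc1)C(=O)N1CCC[C@H]1C(=O)N[C@@H](CCCNC(=N)N)C(=O)CF`: 130 nM
- compound 2 `CC(C)[C@H](NC(=O)Nc1ccccc1)C(=O)N1CCC[C@H]1C(=O)N[C@@H](CCCNC(=N)N)C(=O)CF`: 1520 nM

In a functional assay on OCI-Ly3 cells (Homo sapiens) for inhibition, read by CellTiter-Glo, with stated times of 48 h and 96 h (on this read-out higher numbers stand for weaker inhibition of growth and lower numbers for stronger inhibition of growth), compound 1 has the lower of the two numbers. Compound 3 `CC(C)[C@H](NC(=O)c1ccc(Br)cc1)C(=O)N1CCC[C@@H]1C(=O)N[C@@H](CCCNC(=N)N)C(=O)CF` differs from it only in stereochemistry: the two compounds have the same atoms and bonds; at least one stereo element is drawn with a configuration in one of them and without one in the other: 1 of 4 stereo elements differ; a stereocentre at a saturated ring carbon is drawn S in compound 1 and R in compound 3. For the measured compounds named here, the only measured step, a 12-fold higher number from compound 1 to compound 2 (1.07 log units; beyond the scatter), is a change at another place, and no measured pair tests a stereocentre. Going by the values given here, that large step shows only that a single change can move this read-out well beyond the scatter. A large step towards weaker inhibition is therefore expected, though with wide uncertainty: a 14-fold higher number from compound 1 to compound 3 (1.14 log units; beyond the scatter) is the estimated step. Compound 3 is estimated at 1800 nM, within an expected range of 350 nM to 9000 nM.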

Compound 3, concentration for 50% growth inhibition: > 20000 nM
Compound 3: a limit, no number (the forecaster's own chance of this, stated with the estimate: 15%); middle value at least 11-fold (1.04 log units) from the limit.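

In this assay, the configuration at this saturated ring carbon alone, S in compound 1 and R in compound 3, gives an at least 150-fold higher number from compound 1 to compound 3 (2.18 log units; beyond the scatter). For compound 3, > 20000 nM is a limit of the assay and not a number. For the compounds shown here, this stereocentre, which no earlier pair tested, therefore moves the read-out well beyond the scatter with atoms and bonds unchanged, and of the two configurations only S gives a measurable number.

From the compounds shown here alone, the true size of the step stays open, since it rests on a limit: the limit of > 20000 nM in this assay, at which 1 of the 3 values shown sits. Also open, going by these compounds, is how a methyl group at this ring carbon would read here.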